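A few compounds are considered here, and "the series" means these few. Any claim that something is new, unique, unknown or untested is made for them only; others in the source may bear on it.

Working notes on the series. Compound 2 `OC[C@H]1O[C@@H](n2cnc3c(NCc4ccccc4Br)ncnc32)[C@H](O)[C@@H]1O` is the point of departure. In an ADME assay on NIH3T3 cells (Mus musculus) for cytotoxicity, with a stated time of 72 h (a higher number here means a weaker inhibitor, a lower number a stronger inhibitor), compound 2 gives only a limit, > 166000 nM, no number. That sits on (the limit of > 166000 nM in this assay, at which 1 of the 2 values shown sits). For comparison, compound 1 `OC[C@H]1O[C@@H](n2cnc3c(NCc4cccc(F)c4)ncnc32)[C@H](O)[C@@H]1O` in this assay gives 84000 nM. For the measured compounds named here, the one measured step, an at least 1.9-fold higher number from compound 1 to compound 2 (0.29 log units; that floor lies within the scatter), is the sole guide available for what a change on the benzyl group does here.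

The next compound is compound 3 `OC[C@H]1O[C@@H](n2cnc3c(NCc4ccc(F)cc4Cl)ncnc32)[C@H](O)[C@@H]1O`. It differs from compound 2 as follows: 2-chloro-4-fluorophenyl in place of 2-bromophenyl on a saturated chain carbon bound to a nitrogen on an aromatic ring. This again alters only the substituents on that ring, as the step from compound 1 to compound 2 did, and that step reached no size beyond the scatter. For the step from compound 2 to compound 3 the expectation is therefore no movement beyond the scatter, an at least 1.0-fold lower number from compound 2 to compound 3 (0.01 log units; that floor lies within the scatter). Compound 3 is expected to give about 160000 nM in this assay, with a range from 60000 nM to 450000 nM, and a real chance that once more only a limit is reported.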

Compound 3, half-maximal inhibitory concentration: > 166000 nM
Compound 3: only a limit was reported; the forecaster's own chance of this, stated with the estimate: 55%; middle value at least 1.0-fold (0.01 log units) away from the limit.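

In this assay compound 3 also gives only a limit, > 166000 nM, so a second ring pattern, 2-chloro-4-fluorophenyl, now stands with 2-bromophenyl at the same limit: the limit of > 166000 nM in this assay, at which 2 of the 3 values shown sit. The only readable new step is an at least 1.9-fold higher number from compound 1 to compound 3 (0.29 log units; that floor lies within the scatter), so neither change away from 3-fluorophenyl has yet been shown to exceed the scatter. The step between compound 2 and compound 3 cannot be read, as both values are limits, and swapping bromine for chlorine plus fluorine therefore has no measurable size here.

From the compounds shown here alone, it remains open whether any change at this position moves the number beyond the scatter. Going by these compounds, it is equally open whether an amine or a carboxylic acid on the phenyl ring, or a longer chain in place of the benzyl carbon, would give a number rather than a limit.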